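The source may hold more compounds than are shown below. What is called first, only, known or untested is meant among the compounds shown, and "the series" means these compounds.

In a functional assay on MCF7 cells (Homo sapiens) for antiproliferative activity, read by MTT assay, with a stated time of 24 h (a higher number here means a weaker inhibitor, a lower number a stronger inhibitor), compound 1 (`CCn1c(C(=O)NCCNC(=O)OC(C)(C)C)ccc1C(CC)(CC)c1ccc(OCS(=O)(=O)c2ccccc2)c(C)c1`) gives > 50000 nM, which is a limit of the assay and not a number. Compound 2 (`CCn1c(C(=O)N[C@H](C)CO)ccc1C(CC)(CC)c1ccc(OCS(=O)(=O)c2ccccc2)c(C)c1`) gives 10600 nM and compound 3 (`CCn1c(C(=O)N[C@H](CO)C(C)C)ccc1C(CC)(CC)c1ccc(OCS(=O)(=O)c2ccccc2)c(C)c1`) gives 25500 nM, so compound 3 is the weaker of the two inhibitors with true numbers. Compound 4 (`CCn1c(C(=O)N[C@@H](CO)C(C)C)ccc1C(CC)(CC)c1ccc(OCS(=O)(=O)c2ccccc2)c(C)c1`) changes only one feature: the two compounds have the same atoms and bonds and differ only in configuration as drawn: 1 of 1 stereo elements differ; a stereocentre at a saturated chain carbon is drawn S in compound 3 and R in compound 4. Going by the values given here, no measured step changes configuration alone. The closest guide is a 2.4-fold higher number from compound 2 to compound 3 (0.38 log units; beyond the scatter), a modest step that replaces 1-(hydroxymethyl)ethyl with 1-(hydroxymethyl)-2-methylpropyl. A larger change, an at least 4.7-fold lower number from compound 1 to compound 2 (0.67 log units; beyond the scatter), replaces a whole chain. With no basis for a direction, the expected result is a 1.0-fold lower number from compound 3 to compound 4 (0.01 log units; within the scatter), within the scatter. The estimated value for compound 4 is 25000 nM, with an expected range of 10000 nM to 50000 nM.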

Compound 4, half-maximal inhibitory concentration: 18800 nM
The estimate for compound 4 lay 1.3-fold (0.12 log units) above the measured number; the measured number falls inside the stated range.
By their numbers in this assay, from the lowest: compounds 2, 4 and 3 (each within the scatter of the next, the first and the last beyond it). At a limit, above all of these: compound 1.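

Configuration at this saturated chain carbon had not been tested alone before, and in this assay it makes no clear difference, with a 1.4-fold lower number from compound 3 to compound 4 (0.13 log units; within the scatter). Isopropyl in place of methyl on that carbon gives a 1.8-fold higher number from compound 2 to compound 4 (0.25 log units; within the scatter), so the modest loss seen earlier with compound 3 is not a firm effect of the larger group. The remaining step, an at least 2.6-fold lower number from compound 1 to compound 4 (0.42 log units; beyond the scatter), is only a floor, one end of it being a limit of the assay and not a number.

On these data alone, whether a free amine or a carboxylic acid in place of the hydroxyl, or a longer chain on that carbon, would move the number beyond the scatter stays open.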